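A Chloro-for-Methyl Swap Beneath a Potency Limit

The source may report more compounds than this note shows. Statements on the series, on what has been measured and on what is new or still open speak of the compounds shown alone.

Compound 2, `COc1ccccc1N1CCN(CC2=NS(=O)(=O)c3ccc(C)cc3N2)CC1`, has been tested in a functional assay on Vas deferens for antagonist activity at Alpha-1A adrenergic receptor (Rattus norvegicus) (on this read-out lower numbers stand for lower potency and higher numbers for higher potency (the scale is a negative logarithm)), where compound 2 gives only a limit of < 5. Its nearest relative, compound 1, `COc1ccccc1N1CCN(CC2=NS(=O)(=O)c3ccccc3N2)CC1`, likewise gives a limit of < 5 in this assay. The step that the two limits leave unreadable from compound 1 to compound 2 therefore cannot be sized, because of the limit of < 5 in this assay, at which 2 of the 2 values shown sit. Compound 3, `COc1ccccc1N1CCN(CC2=NS(=O)(=O)c3ccc(Cl)cc3N2)CC1`, differs from compound 2 by chloro in place of methyl on an aromatic carbon. For the measured compounds named here, the only measured step touching the same position is a step that the two limits leave unreadable from compound 1 to compound 2, which offers no readable size and no direction, so the expected step that the limit leaves unreadable from compound 2 to compound 3 is taken as small and of uncertain sign. Compound 3 is therefore expected to land at 4.8, within a range from 4.2 to 5.5, with a considerable chance that this assay again reports only a limit rather than a number.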

Compound 3, negative logarithm of the antagonist equilibrium constant: 5.28
Beside the measured number, compound 3's estimate is 0.48 log units below it, within the range that was stated.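

For the compounds shown here, compound 3 is the first compound here to give a number rather than a limit in this assay, which shows that this position can take a change that lifts the read-out clear of that limit. With chloro in place of methyl the result is a number at least 0.28 log units higher from compound 2 to compound 3 (that floor lies within the scatter), and with chloro in place of hydrogen it is a number at least 0.28 log units higher from compound 1 to compound 3 (that floor lies within the scatter). Both are floors rather than full sizes, and the step between the other two compounds cannot be read, because each of these comparisons rests on a limit: the limit of < 5 in this assay, at which 2 of the 3 values shown sit.

Going by these compounds, how far either step truly reaches stays open, since the real values behind the limits are unknown. Also open, on these data alone, is whether bromo, an amine or a carboxylic acid on the same aromatic carbon would give a number in this assay at all.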